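A few compounds are considered here, and "the series" means these few. Any claim that something is new, unique, unknown or untested is made for them only; others in the source may bear on it.

Compound 1 `C/C(=N\NC(N)=S)c1ccc2[nH]c(-c3ccccc3)nc2c1`: 32000 nM
Compound 2 `COc1ccc(-c2nc3cc(/C(C)=N/NC(N)=S)ccc3[nH]2)cc1`: 13000 nM
Compound 3 `COc1ccc(-c2nc3cc(/C(C)=N/NC(N)=S)ccc3[nH]2)c(OC)c1`: > 100000 nM (a limit)

All three compounds were read in an ADME assay on MDBK cells (Bos taurus) for cytotoxicity, read by MTT assay, with a stated time of 96 h; a higher number here means that more compound is tolerated, a lower number that less compound is tolerated. Compound 2 gives 13000 nM, the lower of the two actual numbers, and compound 1 lies above it. Compound 3 gives > 100000 nM, which is a limit and not a number.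

Compound 4 `C/C(=N\NC(N)=S)c1ccc2[nH]c(C3CCCCC3)nc2c1` has cyclohexyl in place of 4-methoxyphenyl on an aromatic carbon. Among the compounds with values here, no measured step makes this exchange, so only the two methoxy steps bear on it. The first is a 2.5-fold lower number from compound 1 to compound 2 (0.39 log units; beyond the scatter), and the second is an at least 7.6-fold higher number from compound 2 to compound 3 (0.88 log units; beyond the scatter). The number therefore does not follow the count of methoxy groups, and compound 3 goes against any simple trend. Compound 4 carries no methoxy, as compound 1 does not, so a modest rise is expected in this assay, with low confidence. The expected change is a 2.0-fold higher number from compound 2 to compound 4 (0.30 log units; within the scatter). Compound 4 is estimated at 26000 nM, with an expected range of 8000 nM to 85000 nM.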

Compound 4, half-maximal cytotoxic concentration: > 100000 nM
Compound 4 gave a limit, no number; the forecaster's own chance of this, stated with the estimate: 12%; middle value at least 3.8-fold (0.58 log units) from the limit.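

In this assay compound 4 gives > 100000 nM, which is a limit of the assay. The earlier steps shown here changed only methoxy groups on an aromatic ring, whereas here that aromatic ring itself gives way to a non-aromatic ring of carbon only, on the aromatic carbon between two ring nitrogen atoms, and the steps are an at least 7.6-fold higher number from compound 2 to compound 4 (0.88 log units; beyond the scatter) and an at least 3.1-fold higher number from compound 1 to compound 4 (0.49 log units; beyond the scatter). Compound 3 with its aromatic ring and compound 4 without one now stand at the same limit: the limit of > 100000 nM in this assay, at which 2 of the 4 values shown sit.

How far compound 3 and compound 4 lie beyond that limit stays unread, so the two cannot be ordered. Also open, on these data alone, is whether the rise depends on a ring at all, or would persist with a longer chain such as n-hexyl, or with an amine on the cyclohexyl ring.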